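Methoxy Core Analogues and an Expected Weak Cytotoxic Result

This account rests on a few compounds, and the source may have more. Where it says the series, first, only, none or still open, it means among the compounds named here.

Compound 1 `COc1ccc(/C=N/NC(=O)Nc2cc3c(Nc4ccc(F)c(Cl)c4)ncnc3cc2O[C@H]2CCOC2)c(OC)c1OC` and compound 2 `COc1cc(/C=N/NC(=O)Nc2cc3c(Nc4ccc(F)c(Cl)c4)ncnc3cc2O[C@H]2CCOC2)cc(OC)c1OC` share one core. In a functional assay on MCF7 cells (Homo sapiens) for cytotoxicity, read by MTT assay, with a stated time of 72 h (a lower number here means a stronger inhibitor, a higher number a weaker inhibitor), compound 1 gives 33800 nM. In this assay compound 2 gives 26500 nM. The step of a 1.3-fold lower number from compound 1 to compound 2 (0.11 log units; within the scatter) comes from the change (3,4,5-trimethoxyphenyl in place of 2,3,4-trimethoxyphenyl on a carbon with a double bond to nitrogen). Compound 3 `COc1cc2ncnc(Nc3ccc(F)c(Cl)c3)c2cc1NC(=O)N/N=C/c1ccc(OC)c(OC)c1OC` carries a core that differs from that of compound 1 by methyl in place of oxolan-3-yl on an oxygen on an aromatic ring. In this assay compound 3 gives "not active" (no number reported), so no number is reported for it. Compound 4 `COc1cc2ncnc(Nc3ccc(F)c(Cl)c3)c2cc1NC(=O)N/N=C/c1cc(OC)c(OC)c(OC)c1` differs from compound 3 by 3,4,5-trimethoxyphenyl in place of 2,3,4-trimethoxyphenyl on a carbon with a double bond to nitrogen, the same change as from compound 1 to compound 2, since the two places read alike. Because the step of a 1.3-fold lower number from compound 1 to compound 2 (0.11 log units; within the scatter) was within the scatter, compound 4 is expected to stay close to compound 3, which showed no activity. Compound 4 is therefore estimated at 60000 nM, between 20000 nM and 200000 nM, and may again show no number at all.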

Compound 4, half-maximal inhibitory concentration: 30700 nM
For compound 4 the middle estimate is 2.0-fold (0.29 log units) above the measured one; low and high end bracket the measured number.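

Replacing oxolan-3-yl with methyl on an oxygen on an aromatic ring gives a 1.2-fold higher number from compound 2 to compound 4 (0.06 log units; within the scatter), so in this assay this pair, which carries 3,4,5-trimethoxyphenyl, shows no measurable difference between the two cores. The swap from 2,3,4-trimethoxyphenyl to 3,4,5-trimethoxyphenyl can be read only on the core of compound 1, as a 1.3-fold lower number from compound 1 to compound 2 (0.11 log units; within the scatter); the step from compound 3 to compound 4 cannot be read, as compound 3 has no number, so whether the change carries over to the second core is not shown. No measurement here offers an explanation for these results.

The compounds shown leave open how a longer chain or an amine on that oxygen would read in this assay. They also leave open how a carboxylic acid on the trimethoxyphenyl ring would read.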